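This account rests on a few compounds, and the source may have more. Where it says the series, first, only, none or still open, it means among the compounds named here.

In an assay for inhibition of kynurenine 3-monooxygenase (Homo sapiens), read by mass spectrometry, with a stated time of 1 h (on this read-out higher numbers stand for weaker inhibition and lower numbers for stronger inhibition), two compounds have been measured:
compound 1 `C[C@@H](Oc1cc2onc(CCC(=O)O)c2cc1Cl)c1ccc(F)cn1`: 3.16 nM
compound 2 `CC(C)Cc1cc2oc(=O)n(CCC(=O)O)c2cc1Cl`: 12.6 nM

Compound 2 stands at the higher of the two numbers, and the gap to compound 1 lies beyond the usual scatter. Compound 3 `O=C(O)CCn1c(=O)oc2cc(OCC3CCC3)c(Cl)cc21` has not yet been measured. It differs from compound 2 in one place: cyclobutylmethoxy in place of isobutyl on an aromatic carbon. Among the measured compounds shown here, no measured pair shows this change, so the size of the step is open. In this assay a small step toward a lower number is expected, though one close to the scatter. For compound 3 the estimate is 8 nM, between 2.5 nM and 30 nM, an expected step of a 1.6-fold lower number from compound 2 to compound 3 (0.20 log units; within the scatter).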

Compound 3, half-maximal inhibitory concentration: 25.1 nM
The estimate for compound 3 lay 3.1-fold (0.50 log units) below the measured number; low and high end bracket the measured number.
By their numbers in this assay, from the lowest: compound 1; then compounds 2 and 3 (each within the scatter of the next).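

In this assay, cyclobutylmethoxy in place of isobutyl on an aromatic carbon gives a 2.0-fold higher number from compound 2 to compound 3 (0.30 log units; within the scatter), a step within the scatter. This position, ortho to a chloro group, therefore accepts a group with a four-membered ring and a hydrogen-bond acceptor, with no clear change in the read-out. Nothing available explains this result. On these data alone, the oxygen and the ring enter together, so their separate contributions remain open. As far as these compounds go, it also remains open how an amine or a longer chain at this position would compare.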